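The source may hold more compounds than are shown below. What is called first, only, known or untested is meant among the compounds shown, and "the series" means these compounds.

Measured compounds in an ADME assay on Vero cells (Chlorocebus sabaeus) for cytotoxicity, read by MTT assay, with a stated time of 72 h; on this read-out higher numbers stand for lower toxicity in this test and lower numbers for higher toxicity in this test:

- compound 1 `COc1c(N2CCN(CC(C)=O)C(C)C2)c(F)cc2c(=O)c(C(=O)O)cn(C3CC3)c12`: 500 ug/mL
- compound 2 `COc1c(N2CCN(C/C(C)=N/O)C(C)C2)c(F)cc2c(=O)c(C(=O)O)cn(C3CC3)c12`: 177 ug/mL
- compound 3 `COc1c(N2CCN(CC/C(C)=N/NC(N)=O)C(C)C2)c(F)cc2c(=O)c(C(=O)O)cn(C3CC3)c12`: 31.3 ug/mL

Compound 1 gives the highest number of the three in this assay, that is, it is the least toxic here. Its nearest neighbour is compound 2, as the step of a 2.8-fold lower number from compound 1 to compound 2 (0.45 log units; beyond the scatter) shows, and the furthest is compound 3, as the step of a 16-fold lower number from compound 1 to compound 3 (1.20 log units; beyond the scatter) shows. Both of those steps swap the 2-oxopropyl group on the ring amine nitrogen for a larger group, and both lower the number.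

Compound 4 `COc1c(N2CCN(O)C(C)C2)c(F)cc2c(=O)c(C(=O)O)cn(C3CC3)c12` has not yet been measured in this assay. It differs from compound 1 in this way: hydroxy in place of 2-oxopropyl on an amine nitrogen in a ring. Here the group on the ring amine nitrogen becomes smaller rather than larger, so neither measured step is a direct match; both show that changing this group can move the number by a modest to large amount, and both moved it downward. A change of no more than a modest size is therefore expected for compound 4, in the direction of a lower number, as a 1.7-fold lower number from compound 1 to compound 4 (0.22 log units; within the scatter). The estimate for compound 4 in this assay is 300 ug/mL, with a range from 100 ug/mL to 700 ug/mL.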

Compound 4, half-maximal cytotoxic concentration: 19.7 ug/mL
Beside the measured number, compound 4's estimate is 15-fold (1.18 log units) above it; measured number below the stated range.
By their numbers in this assay, from the lowest: compounds 4 and 3 (each within the scatter of the next); then compound 2; then compound 1.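

Read alone, the earlier compounds in this assay could suggest that a larger group on the ring amine nitrogen goes with a lower number, but the smaller hydroxy also brings a 25-fold lower number from compound 1 to compound 4 (1.40 log units; beyond the scatter) and so breaks that reading. The number does not simply follow the size of this group: hydroxy gives a 9.0-fold lower number from compound 2 to compound 4 (0.95 log units; beyond the scatter) and, with the largest group shown, a 1.6-fold lower number from compound 3 to compound 4 (0.20 log units; within the scatter) which leaves those two compounds within the scatter of each other. No measurement shown here accounts for these shifts.

As far as these compounds go, it remains open whether compound 1 stands high through its carbonyl, which a plain propyl chain on the same nitrogen would test. Also open, from the compounds shown here alone, is where a bare hydrogen, a methyl or an amine on that nitrogen would fall.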